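The source may hold more compounds than are shown below. What is called first, only, known or untested is meant among the compounds shown, and "the series" means these compounds.

Measured so far in a functional assay on MCF7 cells (Homo sapiens) for antiproliferative activity, read by sulforhodamine B assay, with a stated time of 72 h, tested at 10 uM; a higher number here means a weaker effect of the compound at the concentration tested, a lower number a stronger effect:
- compound 1, `COc1cc(Br)cc(/C=C/C(=O)c2ccccc2)c1O`: 67%
- compound 2, `COc1cccc(C(=O)/C=C/c2cc(Br)cc(OC)c2O)c1`: 77.3%

Among the measured compounds shown here, compound 2 stands highest of the two numbers; compound 1 is nearest and lower, the single measured step being a number 10.3 percentage points higher from compound 1 to compound 2 (beyond the scatter), modest but beyond the scatter. That step concerns a methoxy entering the ring on the ketone side of the shared core.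

Compound 3, `COc1cccc(C(=O)/C=C/c2cc(Br)ccc2O)c1`, is to be measured in this assay. Against compound 2 the difference is hydrogen in place of methoxy on an aromatic carbon. For the measured compounds named here, the group leaves the ring that carries the hydroxy and bromo groups, at the position ortho to the hydroxy group and meta to the bromo group, not the ring touched by the one measured step.

Going by the values given here, the only step bearing on the change is therefore indirect: a methoxy entering on the other ring of compound 2 raised the number by a modest amount. Removing a methoxy elsewhere gives no firm direction; a small move downward, or none beyond the scatter, is expected, i.e. a step of a number 7.3 percentage points lower from compound 2 to compound 3 (within the scatter) is estimated.

Compound 3 is thus expected to give about 70%, with a range from 55% to 85%.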

Compound 3, a percentage reported as activity, at one concentration (the size of the read-out at that concentration, not a potency): 26.9%
Estimate against measurement, compound 3: 43.1 percentage points above, outside the stated range (below it).
By their numbers in this assay, from the lowest: compound 3; then compound 1; then compound 2.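

In this assay, among the compounds shown here, the methoxy ortho to a hydroxy group and meta to a bromo group carries far more weight than the earlier compounds suggested: the change to hydrogen gives a number 50.4 percentage points lower from compound 2 to compound 3 (beyond the scatter) and thus a much stronger effect at the concentration tested. For the compounds shown here, the only earlier step was a number 10.3 percentage points higher from compound 1 to compound 2 (beyond the scatter) and was modest, on the other ring, so this is the first place where one change moves the read-out by a large amount. No available measurement accounts for the size of this step.

As far as these compounds go, only methoxy and hydrogen can be compared at this place, so it remains open how a fluoro group, an amine or a longer alkoxy chain would read there, and whether any group smaller than methoxy keeps the stronger effect. Also open, from the compounds shown here alone, is whether the same exchange gives a step of similar size without the methoxy on the other ring, and whether the stronger effect seen at this single concentration holds at other concentrations.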